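The compounds below may be only part of what the source reports. "The series", "measured", "known", "first", "only" and "open" are said of these compounds alone.

Of the compounds shown here, three built on a shared core have been measured in a functional assay on HT-29 cells (Homo sapiens) for antiproliferative activity, read by MTT assay, with a stated time of 72 h, tested at 10 uM; a lower number here means less inhibition, a higher number more inhibition at the concentration tested (going by the name of the read-out). Compound 1 `CCCC(=O)Nc1cc(Oc2ccc(Nc3nccc4[nH]cc(-c5ccc(F)cc5)c(=O)c34)cc2F)ccn1` gives 23.5%. Compound 3 `CC(O)C(=O)Nc1cc(Oc2ccc(Nc3nccc4[nH]cc(-c5ccc(F)cc5)c(=O)c34)cc2F)ccn1` gives 47.8%, and compound 2 `CC(C)(O)Cn1cc(-c2ccc(F)cc2)c(=O)c2c(Nc3ccc(Oc4ccnc(NC(=O)C5CC5)c4)c(F)c3)nccc21` gives -2.6%. On these numbers compound 1 stands second highest of the three: nearest to it is compound 3, beyond the scatter above it, and furthest is compound 2, beyond the scatter below it.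

Compound 4 `Nc1nccc(Oc2ccc(Nc3nccc4[nH]cc(-c5ccc(F)cc5)c(=O)c34)cc2F)c1Cl` has not yet been measured. It differs from compound 1 in one place: 2-amino-3-chloropyridin-4-yl in place of 2-((propylcarbonyl)amino)pyridin-4-yl on an oxygen on an aromatic ring. Within the data shown here, the only measured step that changes a single place is a number 24.3 percentage points higher from compound 1 to compound 3 (beyond the scatter), and that step swaps one chain for another on a carbonyl carbon while the 2-((propylcarbonyl)amino)pyridin-4-yl group as a whole stays; the change to compound 4 removes that entire group, so no measured step bears on it directly. Among the measured compounds shown here, compound 2 differs from compound 1 in more than one place, and its value shows only that a related compound can give almost no inhibition. For the measured compounds named here, with no guiding step, the step to compound 4 is expected to be a number 1.5 percentage points higher from compound 1 to compound 4 (within the scatter), with no confident direction. Compound 4 is therefore estimated to give 25%, between -5% and 55%.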

Compound 4, a percentage reported as inhibition, at one concentration (the size of the read-out at that concentration, not a potency): 56.2%
Estimate against measurement, compound 4: 31.2 percentage points below; the measured number lies above the stated range.
By their numbers in this assay, from the lowest: compound 2; then compound 1; then compounds 3 and 4 (each within the scatter of the next).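

In this assay, the amide chain on the pyridine is not required for inhibition: 2-amino-3-chloropyridin-4-yl, with fewer heavy atoms than 2-((propylcarbonyl)amino)pyridin-4-yl, gives a number 32.7 percentage points higher from compound 1 to compound 4 (beyond the scatter). Compound 4 also stands level with the best amide shown, since the step is a number 8.4 percentage points higher from compound 3 to compound 4 (within the scatter), so this place on the oxygen accepts two quite different groups at a similar level of inhibition. Nothing available explains why the change to compound 4 raises the number.

Compound 4 loses the amide carbonyl and chain and gains a chlorine in a single change, so the compounds shown cannot separate the two. A plain 2-aminopyridin-4-yl group, without chlorine, or a 2-amino-3-bromopyridin-4-yl group could show which part goes with the higher inhibition.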